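Methyl for bromo on the 4-bromophenyl amine

The source may hold more compounds than are shown below. What is called first, only, known or untested is meant among the compounds shown, and "the series" means these compounds.

For the measured compounds named here, in a functional assay on HeLa cells (Homo sapiens) for inhibition, read by sulforhodamine B assay (on this read-out higher numbers stand for weaker inhibition and lower numbers for stronger inhibition), compound 3 (`O=C1C=C(Nc2ccc(Br)cc2)C(=O)c2c1nc1n2[C@H]2OC[C@@H](O)[C@H]2OC1`) gives 3830 nM, the only exact number so far. Compound 1 (`O=C1C=C(NC2CCCCC2)C(=O)c2c1nc1n2[C@H]2OC[C@@H](O)[C@H]2OC1`) reads > 16000 nM, which is a limit. Compound 2 (`O=C1C=C(NC2CCCC2)C(=O)c2c1nc1n2[C@H]2OC[C@@H](O)[C@H]2OC1`) reads > 16000 nM, also a limit.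

Compound 4 (`Cc1ccc(NC2=CC(=O)c3nc4n(c3C2=O)[C@H]2OC[C@@H](O)[C@H]2OC4)cc1`) has methyl in place of bromo on an aromatic carbon, para to a large group: methyl in place of bromo on an aromatic carbon.

The nearest measured steps are an at least 4.1-fold lower number from compound 1 to compound 3 (0.62 log units; beyond the scatter) and an at least 4.1-fold lower number from compound 2 to compound 3 (0.62 log units; beyond the scatter). Both replace the whole amine substituent, whereas here the phenyl ring stays, so neither tests this change directly.

No step beyond the scatter is expected, and the estimated change is a 1.3-fold higher number from compound 3 to compound 4 (0.12 log units; within the scatter). For compound 4 the expected value is 5000 nM, with an estimated range of 2000 nM to 13000 nM.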

Compound 4, half-maximal inhibitory concentration: 3860 nM
Estimate against measurement, compound 4: 1.3-fold (0.11 log units) above; measured number inside the range.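

On the aromatic carbon para to a large group, bromo and methyl are interchangeable in this series: a 1.0-fold higher number from compound 3 to compound 4 (0.00 log units; within the scatter). A second aryl amine keeps the gain over the cycloalkyl amines, with an at least 4.1-fold lower number from compound 2 to compound 4 (0.61 log units; beyond the scatter) and an at least 4.1-fold lower number from compound 1 to compound 4 (0.61 log units; beyond the scatter), so that gain does not rest on bromo alone. Both of these steps are bounds rather than sizes: the limit of > 16000 nM in this assay, at which 2 of the 4 values shown sit.

Open, from the compounds shown here alone, is what an unsubstituted phenyl, a methoxy or a carboxylic acid would give at that place. Going by these compounds, the true distance between the aryl and cycloalkyl amines also remains open.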